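This account rests on a few compounds, and the source may have more. Where it says the series, first, only, none or still open, it means among the compounds named here.

Measured in an ADME assay for permeability, using PAMPA, with a stated time of 6 h, at pH 7.4; a lower number here means that the compound crosses the layer more slowly, a higher number that the compound crosses the layer faster:

- Compound 1 `C#CCNC1=CC(=O)c2cccc(OC)c2C1=O`: 18.8 10^-6 cm/s
- Compound 2 `C#CCNC1=CC(=O)c2ccccc2C1=O`: 20.8 10^-6 cm/s
- Compound 3 `C#CCNC1=CC(=O)c2cccc(OCC)c2C1=O`: 18.5 10^-6 cm/s

The three compounds cannot be told apart on these numbers. Compound 2, at 20.8 10^-6 cm/s, stands level with the other two, and every gap among them lies within the scatter of this assay.

The next compound is compound 4 `C#CCN(C)C1=CC(=O)c2ccccc2C1=O`. It differs from compound 2 by one change, (methyl in place of hydrogen on an amine nitrogen), which is methyl in place of hydrogen on an amine nitrogen.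

Going by the values given here, no measured step touches that nitrogen, so the evidence is indirect. The three available steps concern other places. Replacing methoxy with hydrogen on an aromatic carbon gave a 1.1-fold higher number from compound 1 to compound 2 (0.04 log units; within the scatter). Adding ethoxy in place of hydrogen on an aromatic carbon gave a 1.1-fold lower number from compound 2 to compound 3 (0.05 log units; within the scatter). Adding methyl on a saturated chain carbon bound to an oxygen gave a 1.0-fold lower number from compound 1 to compound 3 (0.01 log units; within the scatter). All three stayed within the scatter, but they show only that this read-out held steady under those changes, and they say nothing direct about the amine nitrogen.

No step beyond the scatter is therefore expected, and no direction can be favoured with confidence. The expected change is a 1.1-fold higher number from compound 2 to compound 4 (0.02 log units; within the scatter), an estimate that carries wide uncertainty. For compound 4 the estimated value is 22 10^-6 cm/s, with an expected range from 11 10^-6 cm/s to 42 10^-6 cm/s.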

Compound 4, apparent permeability: 18.5 10^-6 cm/s
Compound 4: the middle estimate sits 1.2-fold (0.08 log units) above what was measured; the range from low to high includes it.
By their numbers in this assay, from the lowest: compounds 3, 4, 1 and 2 (each within the scatter of the next).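

Going by these compounds alone, this is the first measured step at the amine nitrogen, and it extends the steady behaviour seen on the aromatic carbon and the oxygen-bound chain to a new position. In this assay, methyl in place of hydrogen on that nitrogen, the change from propargylamino to methyl(propargyl)amino, gave a 1.1-fold lower number from compound 2 to compound 4 (0.05 log units; within the scatter) and so stayed within the scatter, which means that this position tolerates this one carbon without a readable step on the core of compound 2. Nothing available bears on why the read-out held at this nitrogen.

The compounds shown leave open whether a longer chain such as propyl, or an acetyl group, on the same nitrogen would also stay within the scatter, since one methyl says little about larger or differently built groups there. Also open is whether methyl on that nitrogen would read the same in a compound carrying the methoxy of compound 1 or the ethoxy of compound 3, as the step shown stands on the core of compound 2 alone.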